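The source may hold more compounds than are shown below. What is called first, only, known or untested is meant among the compounds shown, and "the series" means these compounds.

Working notes on the series. In a functional assay on MDA-MB-436 cells (Homo sapiens) for antiproliferative activity, read by MTT assay, with a stated time of 48 h (on this read-out lower numbers stand for stronger inhibition and higher numbers for weaker inhibition), compound 1 `C=CS(=O)(=O)N1CCN(c2ncnc3sc(-c4ccc(OC)cc4)cc23)CC1` gives 28400 nM. For the measured compounds named here, compound 2 `C=CS(=O)(=O)N1CCN(c2ncnc3sc(-c4ccc(C#N)cc4)cc23)CC1` gives 9170 nM, the lowest of the two numbers so far, although that number is still high in absolute terms.

The next compound to be read is compound 3 `C=CS(=O)(=O)N1CCN(c2ncnc3sc(-c4ccc(N5CCN(C)CC5)cc4)cc23)CC1`. It carries 4-methylpiperazin-1-yl in place of cyano on an aromatic carbon of a six-membered aromatic ring of carbon only, para to a large group: 4-methylpiperazin-1-yl in place of cyano on an aromatic carbon.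

Going by the values given here, only one measured step bears on this change, and it was made at the same place: cyano in place of methoxy, a 3.1-fold lower number from compound 1 to compound 2 (0.49 log units; beyond the scatter). That step is modest, though beyond the scatter. Among the compounds with values here, it does not cover a group of this kind, and the data hold no example of a ring-bearing substituent at this place, so it gives a scale for the change but no direction.

No shift beyond the scatter in this assay is therefore the central expectation, with wide uncertainty on both sides. The expected step is a 1.1-fold lower number from compound 2 to compound 3 (0.06 log units; within the scatter). For compound 3 the estimated value is 8000 nM, with an expected range of 2500 nM to 30000 nM.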

Compound 3, half-maximal inhibitory concentration: 8760 nM
For compound 3 the middle estimate is 1.1-fold (0.04 log units) below the measured one; the measured number falls inside the stated range.
By their numbers in this assay, from the lowest: compounds 3 and 2 (each within the scatter of the next); then compound 1.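

At this place on the six-membered aromatic ring, a much larger substituent that brings in a non-aromatic ring leaves the read-out where it was: this assay shows a 1.0-fold lower number from compound 2 to compound 3 (0.02 log units; within the scatter) for 4-methylpiperazin-1-yl in place of cyano. Measured against methoxy, the same group gives a 3.2-fold lower number from compound 1 to compound 3 (0.51 log units; beyond the scatter) and so matches the size of the earlier step, a 3.1-fold lower number from compound 1 to compound 2 (0.49 log units; beyond the scatter) for cyano in place of methoxy, which leaves compound 1 as the weakest of the three and compound 2 and compound 3 within the scatter of each other. No measurement is available that explains this result or links it to any property of the groups.

From the compounds shown here alone, the three compounds cover only methoxy, cyano and 4-methylpiperazin-1-yl at this place, so it remains open whether a carboxylic acid, a morpholine ring, a piperazine without the methyl or a longer chain would move the number beyond the scatter. All three numbers are high in absolute terms, and the compounds shown do not tell whether any change at this place can bring them far lower, or whether that would take a change elsewhere on the shared core.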